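From methyl ester to free carboxy in compound 4

The compounds below may be only part of what the source reports. "The series", "measured", "known", "first", "only" and "open" are said of these compounds alone.

Measured so far:
- compound 1 `COC(=O)[C@@H](NC(=O)CSc1nc(-c2ccccc2)cc(-c2ccc(C)cc2)c1C#N)C(C)C`: 210000 nM
- compound 2 `CC[C@H](C)[C@H](NC(=O)CSc1nc(-c2ccccc2)cc(-c2ccc(C)cc2)c1C#N)C(=O)OC`: > 250000 nM (a limit of the assay, not a number)
- compound 3 `COC(=O)[C@H](CCCNC(=N)N)NC(=O)CSc1nc(-c2ccccc2)cc(-c2ccc(C)cc2)c1C#N`: > 250000 nM (a limit of the assay, not a number)

For the measured compounds named here, in an ADME assay on MDCK cells (Canis lupus familiaris) for cytotoxicity, read by MTT assay, with a stated time of 48 h (a higher number here means that more compound is tolerated, a lower number that less compound is tolerated), compound 1 gives 210000 nM, the only true number available so far. Compound 2 and compound 3 both stand at the limit of > 250000 nM in this assay, at which 2 of the 3 values shown sit.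

Compound 4 `Cc1ccc(-c2cc(-c3ccccc3)nc(SCC(=O)N[C@H](C(=O)O)C(C)C)c2C#N)cc1` has not yet been measured. It differs from compound 1 as follows: hydrogen in place of methyl on an oxygen next to a carbonyl group. In words, hydrogen takes the place of methyl on an oxygen next to a carbonyl group, so methoxycarbonyl becomes carboxy.

Going by the values given here, no measured step makes this change. The two nearest steps both alter the side chain and keep the methoxycarbonyl: an at least 1.1-fold higher number from compound 1 to compound 2 (0.07 log units; that floor lies within the scatter), and an at least 1.1-fold higher number from compound 1 to compound 3 (0.07 log units; that floor lies within the scatter). A third, a step that the two limits leave unreadable from compound 2 to compound 3, cannot be read. These steps therefore offer only indirect guidance, and none shows a change beyond the scatter.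

With compound 1 at 210000 nM as the starting point, no step beyond the scatter is expected in this assay. The expected change is a 1.1-fold higher number from compound 1 to compound 4 (0.04 log units; within the scatter). Compound 4 is estimated at 230000 nM, with an expected range from 110000 nM to 450000 nM. A report of only a limit would also be no surprise.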

Compound 4, half-maximal cytotoxic concentration: > 250000 nM
Compound 4 ended at the assay's limit (the forecaster's own chance of this, stated with the estimate: 50%); middle value at least 1.0-fold (0.03 log units) away from the limit.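

In this assay compound 4 gives > 250000 nM, which is a limit of the assay and not a number: the limit of > 250000 nM in this assay, at which 3 of the 4 values shown sit.

Exchanging methoxycarbonyl for carboxy gives an at least 1.1-fold higher number from compound 1 to compound 4 (0.07 log units; that floor lies within the scatter), so this is the first change shown at the ester itself rather than on the side chain, and its readable part does not go beyond the scatter. The true size of the step stays hidden behind the limit, and the steps linking compound 4 with compound 2 and compound 3 cannot be read, as each joins two limits.

The compounds shown leave open how much of compound 4 the cells actually tolerate, and so whether the free carboxy differs from the methoxycarbonyl of compound 1 at all. They also leave open what an ethyl ester or a primary amide would give in this place, and whether a carboxy paired with the side chain of compound 2 or compound 3 would stay at the limit.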